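Replacing an Arylamine with Piperidine

This account rests on a few compounds, and the source may have more. Where it says the series, first, only, none or still open, it means among the compounds named here.

In a functional assay on MGC-803 cells (Homo sapiens) for inhibition, read by sulforhodamine B assay (a higher number here means a weaker inhibitor, a lower number a stronger inhibitor), compound 2 `Cc1ccc(NC2=CC(=O)c3nc4n(c3C2=O)[C@H]2OC[C@@H](O)[C@H]2OC4)cc1` gives 1420 nM, and compound 1 `COc1ccccc1NC1=CC(=O)c2nc3n(c2C1=O)[C@H]1OC[C@@H](O)[C@H]1OC3` gives 1630 nM, so the two cannot be ranked. Compound 3 `O=C1C=C(N2CCCCC2)C(=O)c2c1nc1n2[C@H]2OC[C@@H](O)[C@H]2OC1` keeps the shared core but has piperidin-1-yl in place of (4-methylphenyl)amino on a double-bonded ring carbon. Among the measured compounds shown here, only one measured step bears on this change, a 1.1-fold lower number from compound 1 to compound 2 (0.06 log units; within the scatter), which lies within the scatter. That step only exchanged one ring on the amine nitrogen for another, so it shows that this swap left this assay little moved, but it does not test removing the whole group. With so little evidence, a modest move towards weaker inhibition is expected, and it could well be larger or absent. The expected change is a 1.8-fold higher number from compound 2 to compound 3 (0.25 log units; within the scatter). For compound 3 the estimated value is 2500 nM, with an expected range of 700 nM to 9000 nM.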

Compound 3, half-maximal inhibitory concentration: > 8000 nM
Compound 3 ended at the assay's limit; the forecaster's own chance of this, stated with the estimate: 5%; at least 3.2-fold (0.50 log units) between middle value and limit.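

Among the compounds shown here, the earlier step between the two arylamines, a 1.1-fold lower number from compound 1 to compound 2 (0.06 log units; within the scatter), suggested that this position tolerates change, but only one aryl ring was being exchanged for another. Replacing the whole group in this assay matters far more: the step is an at least 5.6-fold higher number from compound 2 to compound 3 (0.75 log units; beyond the scatter), and from the other arylamine it is an at least 4.9-fold higher number from compound 1 to compound 3 (0.69 log units; beyond the scatter), so the group on this double-bonded ring carbon does influence inhibition. The value for compound 3 is a limit of the assay and not a number: the limit of > 8000 nM in this assay, at which 1 of the 3 values shown sits.

On these data alone, it remains open which part of the change matters, since the aromatic ring and the hydrogen-bond donor leave together in compound 3. A cyclohexylamino group, which places a non-aromatic ring on an amine that keeps its hydrogen, would separate the two.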